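The source may report more compounds than this note shows. Statements on the series, on what has been measured and on what is new or still open speak of the compounds shown alone.

Compound 1 `COC(=O)[C@@]1(C)CCC=C2[C@@H]1CC[C@@H](C)[C@]2(C)Cc1c[nH]c2ccc(Br)cc12` gives 12000 nM in a functional assay on SW1573 cells (Homo sapiens) for inhibition, read by sulforhodamine B assay, with a stated time of 48 h; a higher number here means a weaker inhibitor of growth, a lower number a stronger inhibitor of growth. Compound 2 `COC(=O)[C@@]1(C)CCC=C2[C@@H]1CC[C@@H](C)[C@]2(C)Cc1c(C)[nH]c2ccc(Br)cc12`, with methyl in place of hydrogen on an aromatic carbon, gives 14000 nM in this assay; the step of a 1.2-fold higher number from compound 1 to compound 2 (0.07 log units; within the scatter) lies within the scatter, so compound 2 stands alongside compound 1 rather than apart from it. Compound 3 `COC(=O)[C@@]1(C)CCC=C2[C@@H]1CC[C@@H](C)[C@]2(C)Cc1c(C)[nH]c2ccc(OC)cc12` changes compound 2 by methoxy in place of bromo on an aromatic carbon. For the measured compounds named here, no measured step involves this exchange; the only step known, a 1.2-fold higher number from compound 1 to compound 2 (0.07 log units; within the scatter), was small. Compound 3 is therefore expected to stay close to compound 2, an expected step of a 1.1-fold higher number from compound 2 to compound 3 (0.06 log units; within the scatter), giving an estimate of 16000 nM, between 6000 nM and 45000 nM.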

Compound 3, concentration for 50% growth inhibition: 15000 nM
Estimate against measurement, compound 3: 1.1-fold (0.03 log units) above, within the range that was stated.
By their numbers in this assay, from the lowest: compounds 1, 2 and 3 (each within the scatter of the next).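

For the compounds shown here, the earlier step changed a different place, so this is the first view of the six-membered aromatic ring of carbon only. Methoxy brings a hydrogen-bond acceptor that bromo lacks, yet in this assay the step is a 1.1-fold higher number from compound 2 to compound 3 (0.03 log units; within the scatter), so this one exchange leaves growth inhibition within the scatter. Nothing available explains why the two groups read alike.

As far as these compounds go, whether an amine or a carboxylic acid at this place would move the number remains open. So does whether methoxy would behave the same way on compound 1.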